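The source may report more compounds than this note shows. Statements on the series, on what has been measured and on what is new or still open speak of the compounds shown alone.

Measured so far in a functional assay on HeLa cells (Homo sapiens) for antiproliferative activity, read by MTT assay, with a stated time of 48 h; a higher number here means a weaker inhibitor, a lower number a stronger inhibitor:
Compound 1, `COc1cc(C(=O)/C(C)=C/c2c[nH]c3ccccc23)cc([Se]C)c1OC`: compound 1 gives 34 nM.
Compound 2, `COc1cc(C(=O)/C=C/c2cn(C)c3ccccc23)cc(N)c1OC`: compound 2 gives 668 nM.
Compound 3, `COc1cc(C(=O)/C(C)=C/c2cn(C)c3ccccc23)cc([Se]C)c1OC`: compound 3 gives 63 nM.

Compound 2 has the highest number of the three, beyond the scatter from both others. For the measured compounds named here, the one paired change seen so far is hydrogen in place of methyl on an aromatic nitrogen, which gave a 1.9-fold lower number from compound 3 to compound 1 (0.27 log units; within the scatter).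

Compound 4, `COc1cc(C(=O)/C=C/c2c[nH]c3ccccc23)cc(N)c1OC`, is not yet measured. It differs from compound 2 by hydrogen in place of methyl on an aromatic nitrogen, the same change as that from compound 3 to compound 1, made on a different core; how the core of compound 2 differs from that of compound 3 is not broken down here.

Going by the values given here, for compound 4 the expected step is a 1.9-fold lower number from compound 2 to compound 4 (0.28 log units; within the scatter), a size close to the earlier one, because the only measured instance of this change is a 1.9-fold lower number from compound 3 to compound 1 (0.27 log units; within the scatter). Compound 4 is therefore estimated at 350 nM in this assay, expected to lie between 180 nM and 700 nM.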

Compound 4, half-maximal inhibitory concentration: 529 nM
For compound 4 the middle estimate is 1.5-fold (0.18 log units) below the measured one, and the stated range covers the measured number.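

In this assay, hydrogen in place of methyl on the aromatic nitrogen gives a 1.3-fold lower number from compound 2 to compound 4 (0.10 log units; within the scatter). The change reads alike on the two cores, and neither step stands beyond the scatter: the same change on two cores in this assay, a 1.9-fold lower number (0.27 log units; within the scatter) from compound 3 to compound 1 and a 1.3-fold lower number (0.10 log units; within the scatter) from compound 2 to compound 4, 1.5-fold (0.17 log units) apart, within the scatter of two such steps. For the compounds shown here, this supports carrying the change between these two cores with little expected shift in the number, but with only two pairs, it does not establish a real direction for the change or show that it would hold on any other core.

The compounds shown leave open whether an ethyl group, a longer chain or an acetyl group on that nitrogen would give a step beyond the scatter. They also leave open what each difference between the core of compound 2 and the core of compound 3 contributes on its own.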